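The compounds below may be only part of what the source reports. "The series", "measured", "known", "first", "only" and "open" are said of these compounds alone.

Compound 1, `Clc1cccc2c1CC2CCN1CCN(c2cccc3c2OCCO3)CC1`, is the starting point of this step. In a functional assay on the whole organism for antagonist activity, with Rattus norvegicus as the target (a higher number here means that more compound is needed for the effect, a lower number that less compound is needed), compound 1 gives 1.25 mg/kg. Two related compounds sit beside it. Compound 3, `COc1cc2c(cc1OC)C(CCN1CCN(c3cccc4c3OCCO4)CC1)C2`, gives 1.25 mg/kg in this assay, the same number as compound 1 at the digits printed. Compound 2, `Fc1cccc2c1CC2CN1CCN(c2cccc3c2OCCO3)CC1`, gives 0.63 mg/kg in this assay. The gap between compound 1 and compound 2 lies within the usual scatter of repeated measurements, as does the gap between compound 1 and compound 3, so the three measured numbers cannot be ranked against one another with confidence; compound 1 and compound 3 simply share the highest number of the three.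

The new compound is compound 4, `C1=C(CCN2CCN(c3cccc4c3OCCO4)CC2)Cc2ccccc21`. It differs from compound 1 in a single place: a group of 9 heavy atoms (9 carbon; one five-membered non-aromatic ring of carbon only, one six-membered aromatic ring of carbon only) in place of a group of 9 heavy atoms (8 carbon, 1 chlorine; one four-membered non-aromatic ring of carbon only, one six-membered aromatic ring of carbon only), on a saturated chain carbon, two bonds along the chain from an amine nitrogen in a ring. Among the compounds with values here, no pair of measured compounds differing in one place exists here, so there is no measured step to lean on. With the three measured numbers all within the scatter of one another, the expectation is a step of none beyond the scatter, in no particular direction: the step of no change at the digits printed from compound 1 to compound 4 (within the scatter) is what is expected. Compound 4 is estimated at 1.25 mg/kg, with a range from 0.3 mg/kg to 5 mg/kg.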

Compound 4, minimum effective dose: 0.31 mg/kg
Compound 4: middle estimate off by 4.0-fold (0.61 log units), on the high side, within the range that was stated.
By their numbers in this assay, from the lowest: compound 4; then compounds 2, 1 and 3 (each within the scatter of the next).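

Within the data shown here, at the place on a saturated chain carbon, two bonds along the chain from an amine nitrogen in a ring, this assay gives a 4.0-fold lower number from compound 1 to compound 4 (0.61 log units; beyond the scatter), the first step in this set of compounds and one that shows this position can respond to a change of group. The group that leaves and the group that enters have the same count of heavy atoms, no hydrogen-bond donors or acceptors and no net charge, so these counts do not separate them, while the differences that remain are the loss of chlorine, a five-membered non-aromatic ring of carbon only in place of a four-membered one, and a double bond outside the aromatic ring. No measurement shown here explains why the number falls.

With these differences all arriving in one step, the compounds shown leave open which of them, alone or together, accounts for the step. Also open, as far as these compounds go, is how the number would respond to a bromine or a nitrile on the six-membered aromatic ring of the entering group, or to a longer chain leading to the amine nitrogen.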